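A few compounds are considered here, and "the series" means these few. Any claim that something is new, unique, unknown or untested is made for them only; others in the source may bear on it.

Measured compounds in a functional assay on NUGC-3 cells (Homo sapiens) for antiproliferative activity, read by sulforhodamine B assay; a higher number here means a weaker inhibitor of growth, a lower number a stronger inhibitor of growth:
Compound 1 `COc1ccc2sc(NC(=O)c3ccc(C(F)(F)F)cc3)nc2c1` — compound 1 returns only the assay limit > 10 ug/mL in this assay (the limit of > 10 ug/mL in this assay, at which 1 of the 3 values shown sits).
Compound 2 `COc1ccc(C(=O)Nc2nc3c(OC)cccc3s2)cc1` — compound 2 gives 3.46 ug/mL in this assay.
Compound 3 `O=C(Nc1nc2ccc([N+](=O)[O-])cc2s1)c1ccc(C(F)(F)F)cc1` — compound 3 gives 1.65 ug/mL in this assay.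

Of the two actual numbers, compound 2 holds the higher one; compound 3 sits lower, and the gap between them is beyond the scatter.

Compound 4 `COc1cccc2sc(NC(=O)c3ccc([N+](=O)[O-])cc3)nc12` is not yet measured. It differs from compound 2 by nitro in place of methoxy on an aromatic carbon; the site is an aromatic carbon of a six-membered aromatic ring of carbon only, para to a large group. Among the measured compounds shown here, no measured pair covers this exchange. The step from compound 2 to compound 4 in this assay is expected to be small, toward a lower number, but likely within the scatter: a 1.4-fold lower number from compound 2 to compound 4 (0.14 log units; within the scatter). Compound 4 is estimated at 2.5 ug/mL, in the range 0.8 ug/mL to 8 ug/mL.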

Compound 4, concentration for 50% growth inhibition: > 10 ug/mL
Compound 4: only a limit was reported; the forecaster's own chance of this, stated with the estimate: 10%; middle value at least 4.0-fold (0.60 log units) from the limit.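

In this assay compound 4 returns only a limit, > 10 ug/mL. Among the compounds shown here, at this aromatic carbon, para to a large group, nitro in place of methoxy gives an at least 2.8-fold higher number from compound 2 to compound 4 (0.46 log units; beyond the scatter), the first single-place step, so growth inhibition at this position depends on the group carried there. The step has only a lower bound, and this limit is shared within the series: the limit of > 10 ug/mL in this assay, at which 2 of the 4 values shown sit.

The compounds shown leave open whether an amine or a carboxylic acid on this carbon would keep growth inhibition, and whether the same exchange behaves alike on another core.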